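Methoxy on the Benzyl Ring of Compound 3

The compounds below may be only part of what the source reports. "The series", "measured", "known", "first", "only" and "open" are said of these compounds alone.

Compound 1: `[O-][n+]1nc(NCOC2CCCCC2)[n+]([O-])c2ccccc21` — in a functional assay on PC-3 cells (Homo sapiens) for cytotoxicity, read by MTT assay, with a stated time of 72 h (a higher number here means a weaker inhibitor, a lower number a stronger inhibitor), compound 1 gives 6670 nM.
Compound 2: `O=[N+]([O-])c1cccc(COCNc2n[n+]([O-])c3ccccc3[n+]2[O-])c1` — compound 2 gives > 100000 nM, a limit of the assay and not a number.
Compound 3: `[O-][n+]1nc(NCOCc2ccccc2)[n+]([O-])c2ccccc21` — compound 3 gives 11900 nM.

Among the two numbers recorded, compound 3 carries the higher one, though a 1.8-fold higher number from compound 1 to compound 3 (0.25 log units; within the scatter), so the two stand together. Compound 2 reported only (the limit of > 100000 nM in this assay, at which 1 of the 3 values shown sits). Within the data shown here, from that limit, an at least 8.4-fold lower number from compound 2 to compound 3 (0.92 log units; beyond the scatter), the one step that touches the aromatic ring of the benzyl group.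

Compound 4, `COc1ccc(COCNc2n[n+]([O-])c3ccccc3[n+]2[O-])cc1`, is the next compound along that ring: methoxy in place of hydrogen on an aromatic carbon. Among the measured compounds shown here, the only measured step at this ring is the one from compound 2, where a substituent on the ring went with a number at the limit, and the direction of the present change is the reverse of that step. On that evidence a rise of modest size in the number is expected, a 2.1-fold higher number from compound 3 to compound 4 (0.32 log units; beyond the scatter), with a real chance that the reading again comes as a limit. Compound 4 is therefore estimated at 25000 nM, within a range from 7000 nM to 90000 nM.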

Compound 4, half-maximal inhibitory concentration: 52800 nM
For compound 4 the middle estimate is 2.1-fold (0.32 log units) below the measured one; the measured number falls inside the stated range.
By their numbers in this assay, from the lowest: compounds 1 and 3 (each within the scatter of the next); then compound 4. At a limit, above all of these: compound 2.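

In this assay, among these compounds, this is the first step at the benzyl ring that ends on a number rather than a limit: a 4.4-fold higher number from compound 3 to compound 4 (0.65 log units; beyond the scatter). The change from phenyl to 4-methoxyphenyl thus moves the reading beyond the scatter, and it shows that a ring substituent other than nitro also goes with a higher number than the unsubstituted ring of compound 3. Both ring-substituted compounds shown lie on the same side of compound 3 and neither goes against this, though the pattern rests on only those two groups.

Compound 2 remains a limit and not a number, so the size of its step cannot be set against that of compound 4: the limit of > 100000 nM in this assay, at which 1 of the 4 values shown sits. Still open, as far as these compounds go, is whether a hydroxyl, an amine or a carboxylic acid at this ring place would follow the same direction.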